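Amino on the benzamido group: compound 3 to compound 4

This account rests on a few compounds, and the source may have more. Where it says the series, first, only, none or still open, it means among the compounds named here.

The series is followed in an assay on isolated protein for inhibition of Rho-associated protein kinase 1 (Homo sapiens), read by scintillation counting, radiometric assay and 33P incorporation, with a stated time of 40 min, in the presence of a further agent that is not named here; a higher number here means a weaker inhibitor, a lower number a stronger inhibitor. Compound 1 `CN(C)c1ccc(C(=O)Nc2cccc(NC(=O)COc3ccc4c(c3)NC(=O)CC4)c2)cc1` gives > 10000 nM, which is a limit of the assay and not a number. Compound 2 `CN(C)c1ccc(C(=O)Nc2cccc(NC(=O)COc3ccc4c(c3)OCCO4)c2)cc1` likewise gives > 10000 nM, again a limit. The step that the two limits leave unreadable from compound 1 to compound 2 is therefore not readable; both of these values sit at the limit of > 10000 nM in this assay, at which 2 of the 3 values shown sit. Within the data shown here, compound 3 `O=C(COc1ccc2c(=O)ccoc2c1)Nc1cccc(NC(=O)c2ccccc2)c1` gives 120 nM, the only number in the set, so it cannot be ranked against the other two beyond noting that it alone returns a number.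

Compound 4 `Nc1cccc(C(=O)Nc2cccc(NC(=O)COc3ccc4c(=O)ccoc4c3)c2)c1` differs from compound 3 by amino in place of hydrogen on an aromatic carbon: phenyl becomes 3-aminophenyl, benzamido becomes ((3-aminophenyl)carbonyl)amino. Among the measured compounds shown here, no measured pair touches this part of the molecule; the only step present concerns the group on the oxygen on the saturated carbon and is unreadable in any case. For the measured compounds named here, with no precedent, the step of no change at the digits printed from compound 3 to compound 4 (within the scatter) is expected to stay within the scatter of repeated measurements, no direction favoured. Compound 4 is accordingly estimated at 120 nM, within 40 nM to 400 nM.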

Compound 4, half-maximal inhibitory concentration: 670 nM
Compound 4: middle estimate off by 5.6-fold (0.75 log units), on the low side; the whole stated range lies below it.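

The benzoyl end of the series responds to substitution: in this assay, amino in place of hydrogen on an aromatic carbon, turning phenyl into 3-aminophenyl, gives a 5.6-fold higher number from compound 3 to compound 4 (0.75 log units; beyond the scatter). Among these compounds, this is the first readable step and the first to touch this part of the molecule, and it shows that one added nitrogen at this place moves the value beyond the scatter in the weaker direction while compound 4 still returns a number. Nothing measured here gives a cause for this step.

Whether the loss belongs to the amino group itself or to any substituent at this place stays open, since no methyl, methoxy or fluoro group stands here in the compounds shown. Also open, as far as these compounds go, is how an aminomethyl group or a carboxylic acid would read in place of the amino of compound 4.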